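Chloro on the Phenyl Ring, Tried on a Second Core

The source may hold more compounds than are shown below. What is called first, only, known or untested is meant among the compounds shown, and "the series" means these compounds.

Measured so far in a functional assay on A549 cells (Homo sapiens) for antiproliferative activity, read by MTT assay, with a stated time of 48 h; on this read-out higher numbers stand for weaker inhibition and lower numbers for stronger inhibition:
Compound 1, `c1ccc(-c2nnc(-c3cn4ccccc4n3)o2)cc1`, gives 23400 nM.
Compound 2, `Clc1ccc(-c2nnc(-c3cn4ccccc4n3)o2)cc1`, gives 32400 nM.
Compound 3, `Cc1cc(Br)c2nc(-c3nnc(-c4ccccc4)o3)cn2c1`, gives 14500 nM.

Compound 2 differs from compound 1 by chloro in place of hydrogen on an aromatic carbon, and that change gave a 1.4-fold higher number from compound 1 to compound 2 (0.14 log units; within the scatter). Compound 3 has a different core from compound 1; the difference between the two cores is not broken down here. Compound 4, `Cc1cc(Br)c2nc(-c3nnc(-c4ccc(Cl)cc4)o3)cn2c1`, is not yet measured and differs from compound 3 by chloro in place of hydrogen on an aromatic carbon, the same change as from compound 1 to compound 2. Within the data shown here, since the only precedent is a 1.4-fold higher number from compound 1 to compound 2 (0.14 log units; within the scatter), the step is expected to be about as small: a 1.4-fold higher number from compound 3 to compound 4 (0.14 log units; within the scatter). Compound 4 is therefore estimated at 20000 nM in this assay, with a likely range from 9000 nM to 45000 nM.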

Compound 4, half-maximal inhibitory concentration: 43500 nM
Compound 4: the middle estimate sits 2.2-fold (0.34 log units) below what was measured; low and high end bracket the measured number.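

In this assay chloro in place of hydrogen gave a 3.0-fold higher number from compound 3 to compound 4 (0.48 log units; beyond the scatter) on the second core, which is a real loss of inhibition. Set beside the earlier step, the change does not behave measurably differently on the two cores: the same change on two cores in this assay, a 1.4-fold higher number (0.14 log units; within the scatter) from compound 1 to compound 2 and a 3.0-fold higher number (0.48 log units; beyond the scatter) from compound 3 to compound 4, 2.2-fold (0.34 log units) apart, within the scatter of two such steps. This fits the change carrying over between these two cores, but the step on the core of compound 1 lies within the scatter, and two pairs cannot show that the same would hold on any further core.

The compounds shown leave open what a group other than chloro, such as methoxy or an amine, would do in the same place. They also leave open how each core would respond to it.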